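This account rests on a few compounds, and the source may have more. Where it says the series, first, only, none or still open, it means among the compounds named here.

Compound 1 `COc1cc(N2CCN(C(=O)N3CCC(O)C3)CC2)ccc1Nc1nc(NC2CCCCC2)c2nc[nH]c2n1` in a functional assay on HCT-116 cells (Homo sapiens) for inhibition (a higher number here means that more compound is needed for the effect, a lower number that less compound is needed), gives 100 nM

Compound 2 `COc1cc(N2CCC(C(=O)N3CCC(N(C)C)C3)CC2)ccc1Nc1nc(NC2CCCCC2)c2nc[nH]c2n1` in this assay gives 77 nM

On these numbers, compound 2 (77 nM) stands level with compound 1 (100 nM), since the two values lie within the usual scatter of repeated measurements.

Compound 3 `COc1cc(N2CCC(CC(=O)N3CCCC3)CC2)ccc1Nc1nc(NC2CCCCC2)c2nc[nH]c2n1` shares the core of compound 2 but has no value yet. In compound 3, ((pyrrolidin-1-yl)carbonyl)methyl stands in place of (3-(dimethylamino)pyrrolidin-1-yl)carbonyl on a saturated ring carbon of the six-membered non-aromatic ring with 1 nitrogen. Counted out, the change is ((pyrrolidin-1-yl)carbonyl)methyl in place of (3-(dimethylamino)pyrrolidin-1-yl)carbonyl on a saturated ring carbon in full.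

Among the measured compounds shown here, no pair of measured compounds differs in just one place, so the data hold no direct guide to a change like this one. For the measured compounds named here, the only hint is that compound 1 and compound 2, though built differently at this end of the molecule, gave values within the scatter of each other. No shift beyond the scatter is therefore expected, and the range must stay wide.

The expected step of a 1.3-fold higher number from compound 2 to compound 3 (0.11 log units; within the scatter) is only an estimate.

For compound 3 the estimated value in this assay is 100 nM (expected range 30 nM to 300 nM).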

Compound 3, half-maximal effective concentration: 26 nM
Beside the measured number, compound 3's estimate is 3.8-fold (0.59 log units) above it; the measured number lies below the stated range.
By their numbers in this assay, from the lowest: compound 3; then compounds 2 and 1 (each within the scatter of the next).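

In this assay, among the compounds shown here, the only pair differing in one place shows that the group on this saturated ring carbon can move the number: putting ((pyrrolidin-1-yl)carbonyl)methyl in place of (3-(dimethylamino)pyrrolidin-1-yl)carbonyl gives a 3.0-fold lower number from compound 2 to compound 3 (0.47 log units; beyond the scatter) as a modest step beyond the scatter. The dimethylamino group is therefore not needed to reach a value at this level, and a smaller group with one hydrogen-bond acceptor fewer serves at least as well here. Nothing measured here explains why the number falls.

As far as these compounds go, this single step changes two things together, as the dimethylamino group leaves the pyrrolidine ring and a methyl link appears between the saturated ring carbon and the carbonyl, so the share of each remains unknown. Plain (pyrrolidin-1-yl)carbonyl on this carbon, or ((3-(dimethylamino)pyrrolidin-1-yl)carbonyl)methyl, would pull the two apart, while a longer chain before the carbonyl or a carboxylic acid in place of the pyrrolidine amide remains an open question.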